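Furan for Thiophene on the Shared Core

The source may report more compounds than this note shows. Statements on the series, on what has been measured and on what is new or still open speak of the compounds shown alone.

Among the measured compounds shown here, compound 1 `COc1ncnc2c1c(-c1cccs1)cn2[C@@H]1O[C@H](CO)[C@@H](O)[C@H]1O` is the only member of this set with a number rather than a limit: in an ADME assay on MRC5 cells (Homo sapiens), read by MTT assay, with a stated time of 72 h (on this read-out higher numbers stand for weaker inhibition and lower numbers for stronger inhibition), compound 1 gives 43200 nM. Compound 2 `Cc1ncnc2c1c(-c1cccs1)cn2[C@@H]1O[C@H](CO)[C@@H](O)[C@H]1O` stops at the limit of this assay, > 100000 nM. Compound 3 `CN(C)c1ncnc2c1c(-c1cccs1)cn2[C@@H]1O[C@H](CO)[C@@H](O)[C@H]1O` likewise reaches only the limit, > 100000 nM. Two of the three values thus sit at the limit of > 100000 nM in this assay, at which 2 of the 3 values shown sit. The steps of an at least 2.3-fold higher number from compound 1 to compound 2 (0.36 log units; beyond the scatter) and an at least 2.3-fold higher number from compound 1 to compound 3 (0.36 log units; beyond the scatter) both replace the methoxy group, so neither bears on the change now at hand. Compound 4 `COc1ncnc2c1c(-c1ccco1)cn2[C@@H]1O[C@H](CO)[C@@H](O)[C@H]1O` differs from compound 1 at a different site: furan-2-yl in place of thiophen-2-yl on an aromatic carbon. For the measured compounds named here, with no measured step touching that group, one expects no step beyond the scatter, a 1.0-fold higher number from compound 1 to compound 4 (0.02 log units; within the scatter). Compound 4 is therefore estimated at 45000 nM, within 15000 nM to 100000 nM.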

Compound 4, half-maximal inhibitory concentration: 1700 nM
The estimate for compound 4 lay 26-fold (1.42 log units) above the measured number; the measured number lies below the stated range.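

In this assay this position proves sensitive: furan-2-yl in place of thiophen-2-yl gives a 25-fold lower number from compound 1 to compound 4 (1.41 log units; beyond the scatter), although the two groups differ only in the ring hetero atom, oxygen for sulfur. The earlier steps shown here all replaced the methoxy group and ran upward, whereas this one, with methoxy kept, runs downward. Nothing measured here accounts for the size of this step.

As far as these compounds go, whether furan-2-yl gives a similar step alongside methyl or dimethylamino remains open. Also open, from the compounds shown here alone, is what a phenyl ring or a pyridine ring would give at this place.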